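From compound 1 to compound 4: adding a nitro

This account rests on a few compounds, and the source may have more. Where it says the series, first, only, none or still open, it means among the compounds named here.

Measured so far in a toxicity assay on THP-1 cells (Homo sapiens) for inhibition (a lower number here means that less compound is tolerated, a higher number that more compound is tolerated), with these results
- Compound 1 `Cn1c(-c2ccccc2)cnc1NC(=O)c1ccc(F)cc1` gives > 100000 nM as a limit
- Compound 2 `Cn1c(-c2ccccc2[N+](=O)[O-])cnc1NC(=O)c1ccc(F)cc1` gives 31000 nM as a number
- Compound 3 `Cn1c(-c2ccccc2)cnc1NC(=O)c1ccc(Cl)cc1` gives > 100000 nM as a limit

Compound 1 gives > 100000 nM in this assay and this is a limit of the assay, not a number. For the measured compounds named here, it is the limit of > 100000 nM in this assay, at which 2 of the 3 values shown sit, so compound 1 offers no exact value to step from.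

Compound 4 `Cn1c(-c2ccc([N+](=O)[O-])cc2)cnc1NC(=O)c1ccc(F)cc1` has not yet been measured. It differs from compound 1 by nitro in place of hydrogen on an aromatic carbon with nitro in place of hydrogen on an aromatic carbon, para to a large group.

The measured step closest to this is an at least 3.2-fold lower number from compound 1 to compound 2 (0.50 log units; beyond the scatter) which is beyond the scatter and carries the same exchange. The other measured step is a step that the two limits leave unreadable from compound 1 to compound 3 and it involves no nitro.

Going by the values given here, compound 2 at 31000 nM is the only measured nitro compound, so a lower number is also expected for compound 4. The expected change is an at least 2.5-fold lower number from compound 1 to compound 4 (0.39 log units; beyond the scatter) in this assay and it remains uncertain. For compound 4 the estimated value is 40000 nM (expected range 15000 nM to 100000 nM).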

Compound 4, half-maximal cytotoxic concentration: > 50000 nM
Compound 4 ended at the assay's limit (the forecaster's own chance of this, stated with the estimate: 25%); at least 1.2-fold (0.09 log units) between middle value and limit.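

Compound 1 and compound 4 each give a limit, not a number, in this assay, and no step can be read between them. The compounds shown leave open whether nitro para to a large group lowers the number, as the nitro of compound 2 does.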